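This account rests on a few compounds, and the source may have more. Where it says the series, first, only, none or still open, it means among the compounds named here.

Three compounds built on one shared core were examined in a functional assay on MCF7 cells (Homo sapiens) for cytotoxicity, read by MTT assay, with a stated time of 24 h, tested at 1.6 ug/mL; on this read-out lower numbers stand for a weaker effect and higher numbers for a stronger effect at the one concentration tested. Compound 1 `Cn1c(-c2ccc(NC(=O)CSc3nc4ccccc4o3)cc2)nc(-c2ccccc2)c1-c1ccccc1` gives 27.4%, compound 2 `Cn1nnnc1SCC(=O)Nc1ccc(-c2nc(-c3ccccc3)c(-c3ccccc3)n2C)cc1` gives 34.3%, and compound 3 `Cc1nnc(SCC(=O)Nc2ccc(-c3nc(-c4ccccc4)c(-c4ccccc4)n3C)cc2)s1` gives 37.5%, the highest of the three numbers, although its gap to compound 2 lies within the scatter. The measured steps were a number 6.9 percentage points higher from compound 1 to compound 2 (within the scatter), a number 10.1 percentage points higher from compound 1 to compound 3 (beyond the scatter) and a number 3.2 percentage points higher from compound 2 to compound 3 (within the scatter). Compound 4 `CCN1CCN(CC(=O)Nc2ccc(-c3nc(-c4ccccc4)c(-c4ccccc4)n3C)cc2)CC1` differs from compound 3 by 4-ethylpiperazin-1-yl in place of (5-methyl-1,3,4-thiadiazol-2-yl)sulfanyl on a saturated chain carbon bound to a carbonyl carbon. Among the compounds with values here, each measured step only exchanged the ring on the sulfur, so no step bears directly on this change; the narrow spread among compounds 1 to 3 gives no ground to expect a step beyond the scatter in either direction. Compound 4 is estimated at 33%, within a range from 20% to 46%. For compound 4 the expected step is a number 4.5 percentage points lower from compound 3 to compound 4 (within the scatter).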

Compound 4, a percentage reported as activity, at one concentration (the size of the read-out at that concentration, not a potency): 14.6%
The estimate for compound 4 lay 18.4 percentage points above the measured number; measured number outside the range, below it.
By their numbers in this assay, from the lowest: compound 4; then compounds 1, 2 and 3 (each within the scatter of the next, the first and the last beyond it).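

In this assay, 4-ethylpiperazin-1-yl on a saturated chain carbon bound to a carbonyl carbon gives a number 22.9 percentage points lower from compound 3 to compound 4 (beyond the scatter) and a number 19.7 percentage points lower from compound 2 to compound 4 (beyond the scatter) and a number 12.8 percentage points lower from compound 1 to compound 4 (beyond the scatter). Each of these steps is larger than any step among the three sulfur-linked compounds, so this position tolerates exchange of the ring on the sulfur better than loss of the whole sulfanyl group for this piperazine. No evidence is available to explain this result. The compounds shown leave open whether the fall belongs to the piperazine ring, its ethyl group or the missing sulfur, and whether morpholin-4-yl, 4-methylpiperazin-1-yl or diethylamino on the same carbon would behave alike.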